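The source may hold more compounds than are shown below. What is called first, only, known or untested is meant among the compounds shown, and "the series" means these compounds.

Working notes on the urea series.

Compound 2 is `C[C@@H](NC(=O)Nc1ccc(F)cc1)c1ccccc1`. In an ADME assay on the whole organism with Oryza sativa as the target, tested at 0.1 uM (a higher number here means a weaker effect of the compound at the concentration tested, a lower number a stronger effect), compound 2 gives 98%. Going by the values given here, the only other measured member, compound 1, is `CCOC(=O)c1ccc(NC(=O)N[C@H](C)c2ccccc2)cc1`; in this assay compound 1 gives 101%. Among the compounds with values here, the two numbers lie within the scatter of each other, and the single measured step, a number 3 percentage points lower from compound 1 to compound 2 (within the scatter), concerns fluoro in place of ethoxycarbonyl on an aromatic carbon.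

The next compound, compound 3, is `Cc1cc(F)ccc1NC(=O)N[C@H](C)c1ccccc1`. Against compound 2 the change is methyl in place of hydrogen on an aromatic carbon. Within the data shown here, no measured step concerns methyl in place of hydrogen, so none bears directly on this change; the one step available, from ethoxycarbonyl to fluoro, stayed within the scatter, and both measured numbers sit close to full activity. Nothing in the data points to a step beyond the scatter in this assay in either direction.

The step thus expected is a number 1 percentage points lower from compound 2 to compound 3 (within the scatter). Compound 3 is therefore estimated at 97% in this assay, with a range from 84% to 106%.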

Compound 3, a percentage reported as activity, at one concentration (the size of the read-out at that concentration, not a potency): 100%
Compound 3: middle estimate off by 3 percentage points, on the low side; the measured number falls inside the stated range.
By their numbers in this assay, from the lowest: compounds 2, 3 and 1 (each within the scatter of the next).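

In this assay, methyl in place of hydrogen on an aromatic carbon, ortho to a large group and meta to a fluoro group, gives a number 2 percentage points higher from compound 2 to compound 3 (within the scatter). The earlier step swapped one group for another, whereas this one adds a methyl at a carbon that carried only hydrogen in compound 2 and keeps the fluoro group, so the series now shows that a single added carbon at this place also leaves the read-out within the scatter. No supporting measurement bears on this result, and the data offer no explanation for it.

Going by these compounds, whether a larger or differently built group at this same place, such as an ethyl chain, a methoxy group, an amine or a carboxylic acid, would give a step beyond the scatter remains open. The compounds shown also leave open whether any change elsewhere, for instance on the other aromatic ring or at the methyl on the chiral carbon, would move the number in this assay at all.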